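Cycloheptylcarbamoyl series: a phenyl added to compound 1

The source may report more compounds than this note shows. Statements on the series, on what has been measured and on what is new or still open speak of the compounds shown alone.

Measured so far:
compound 1 `Cc1ccc(C(=O)NC2CCCCCC2)c(=O)n1Cc1ccc(F)cc1` — > 10000 nM
compound 2 `Cc1nc(OCc2ccc(F)cc2)c(C(=O)NC2CCCCCC2)cc1-c1ccc(F)cc1` — > 10000 nM
compound 3 `CC(=O)N[C@@H]1[C@@H](O)[C@H](O)[C@@H](CO)O[C@H]1NC(=O)c1cc(Br)c(C)n(Cc2ccc(F)cc2)c1=O` — > 10000 nM

All three readings come from an assay on HEK293 cells for inhibition of Monoacylglycerol lipase ABHD6 (Homo sapiens), read by scintillation counting, with stated times of 30 min and 5 min; a lower number here means a stronger inhibitor, a higher number a weaker inhibitor. For compound 1 the value > 10000 nM is a limit of the assay, not a number. For compound 2 the value > 10000 nM is likewise a limit. For compound 3 the value > 10000 nM is a limit as well. Compound 1 therefore stands nowhere in particular on these numbers: it sits at the limit of > 10000 nM in this assay, at which 3 of the 3 values shown sit, together with the other two, and no ordering among compounds 1, 2 and 3 can be drawn from what is shown.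

Compound 4 `Cc1c(-c2ccccc2)cc(C(=O)NC2CCCCCC2)c(=O)n1Cc1ccc(F)cc1` has not been measured. It differs from compound 1 by phenyl in place of hydrogen on an aromatic carbon, in words phenyl in place of hydrogen on an aromatic carbon. Among the measured compounds shown here, no step between measured compounds is available to size this change against, since every reading so far is a limit. The step in this assay is expected to be an at least 1.2-fold lower number from compound 1 to compound 4 (0.09 log units; that floor lies within the scatter), and compound 4 is expected most likely to return a limit again. Should a number be obtained, compound 4 is estimated at 8000 nM, between 1500 nM and 30000 nM.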

Compound 4, half-maximal inhibitory concentration: > 10000 nM
Compound 4: a limit, no number (the forecaster's own chance of this, stated with the estimate: 65%); middle value at least 1.2-fold (0.09 log units) from the limit.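

Compound 4, like compound 1, returns a limit and not a number in this assay so the step from compound 1 to compound 4, phenyl in place of hydrogen on an aromatic carbon, cannot be read: the limit of > 10000 nM in this assay, at which 4 of the 4 values shown sit.

The compounds shown leave open whether any change to the core of compound 1 gives a measurable number in this assay at all.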